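The source may report more compounds than this note shows. Statements on the series, on what has been measured and on what is new or still open speak of the compounds shown alone.

Compound 1 `CN(C)CCCCCn1c2c(c3ccccc31)C(=O)c1c[n+]([O-])c3ccccc3c1C2=O`: 560 nM
Compound 2 `O=C1c2c[n+]([O-])c3ccccc3c2C(=O)c2c1c1ccccc1n2CCCCn1ccnc1`: 350 nM
Compound 3 `O=C1c2c[n+]([O-])c3ccccc3c2C(=O)c2c1c1ccccc1n2Cc1cn([C@@H]2C[C@H](O)[C@@H](CO)O2)nn1`: 20 nM

All three values come from a functional assay on A-375 cells (Homo sapiens) for cytotoxicity, read by MTT assay, with a stated time of 72 h; a higher number here means a weaker inhibitor, a lower number a stronger inhibitor. Compound 3 has the lowest number of the three, and its distance to each of the other two lies beyond the scatter. The next compound to consider is compound 4 `CC1(C)OCC(Cn2cc(Cn3c4c(c5ccccc53)C(=O)c3c[n+]([O-])c5ccccc5c3C4=O)nn2)O1`, which differs from compound 3 in one group: (2,2-dimethyl-1,3-dioxolan-4-yl)methyl in place of 4-hydroxy-5-(hydroxymethyl)oxolan-2-yl on an aromatic nitrogen. The exchange is (2,2-dimethyl-1,3-dioxolan-4-yl)methyl in place of 4-hydroxy-5-(hydroxymethyl)oxolan-2-yl, on an aromatic nitrogen of a five-membered aromatic ring with 3 nitrogen.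

For the measured compounds named here, only one single-site step has been measured in this set, a 1.6-fold lower number from compound 1 to compound 2 (0.20 log units; within the scatter). It lies within the scatter and concerns a group on a saturated chain, so it does not bear directly on this exchange. Going by the values given here, no measured step covers the group that leaves or the group that enters. The remaining guide is the spread of values: compound 3 stands at 20 nM, whereas compound 2 stands at 350 nM, although these two differ in more than one place. With compound 3 at the low end of this small set, a move upward seems more likely than a further drop. The expected change in this assay is an estimated 4.0-fold higher number from compound 3 to compound 4 (0.60 log units; beyond the scatter). For compound 4 the estimated value is 80 nM, with an expected range from 20 nM to 350 nM.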

Compound 4, half-maximal inhibitory concentration: 330 nM
The estimate for compound 4 lay 4.1-fold (0.62 log units) below the measured number; the range from low to high includes it.
By their numbers in this assay, from the lowest: compound 3; then compounds 4, 2 and 1 (each within the scatter of the next).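

For the compounds shown here, the exchange on the aromatic nitrogen of the five-membered aromatic ring with 3 nitrogen gives, in this assay, a 17-fold higher number from compound 3 to compound 4 (1.22 log units; beyond the scatter) and so provides the first single-site evidence that the number in this assay responds to the group at this position, whereas the only earlier step, on a saturated chain, lay within the scatter. The leaving and entering groups both have 8 heavy atoms, so that count does not separate them, while 4-hydroxy-5-(hydroxymethyl)oxolan-2-yl has 2 hydrogen-bond donors and 3 defined stereocentres and (2,2-dimethyl-1,3-dioxolan-4-yl)methyl has 0 hydrogen-bond donors and none of the stereocentres. No measurement in hand shows which of these differences accounts for the step.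

The compounds shown leave the hydroxyl groups, the ring and the stereocentres of compound 3 tied together, so the effect of each alone remains open. A 2,3-dihydroxypropyl group on the same nitrogen, or an amine in place of the hydroxyl groups on the oxolane ring, would help to separate these features.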